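This account rests on a few compounds, and the source may have more. Where it says the series, first, only, none or still open, it means among the compounds named here.

Of the compounds shown here, three have so far been measured in a functional assay on cells (Neutrophil, Homo sapiens) for inhibition, with a stated time of 10 min; a lower number here means a stronger inhibitor, a higher number a weaker inhibitor. Compound 2 `CCOC(=O)c1cnn(CC(C)O)c1NC(=O)Nc1cccc(F)c1` gives 0.0007 nM, the lowest number of the three. Compound 1 `CCCC(O)Cn1ncc(C(=O)OCC)c1NC(=O)NCc1ccccc1` gives 0.0032 nM, and compound 3 `CCCC(O)Cn1ncc(C(=O)OCC)c1NC(=O)NC(C)C` gives 1 nM. Going by the values given here, the one measured step, a 310-fold higher number from compound 1 to compound 3 (2.49 log units; beyond the scatter), concerns a different part of the molecule and does not bear on the change considered here. Compound 4 `CCOC(=O)c1cnn(CC(C)O)c1NC(=O)Nc1ccccc1F` has not yet been measured; it differs from compound 2 by 2-fluorophenyl in place of 3-fluorophenyl on an amide-type nitrogen. Among the compounds with values here, no measured pair shows what exchanging 3-fluorophenyl for 2-fluorophenyl does, so the only guide is the value of compound 2, and no step beyond the scatter is expected. The step from compound 2 to compound 4 is estimated as a 1.4-fold higher number from compound 2 to compound 4 (0.15 log units; within the scatter). Compound 4 is therefore expected to give 0.001 nM, within a range from 0.0002 nM to 0.005 nM.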

Compound 4, half-maximal inhibitory concentration: 0.00055 nM
For compound 4 the middle estimate is 1.8-fold (0.26 log units) above the measured one; measured number inside the range.
By their numbers in this assay, from the lowest: compounds 4 and 2 (each within the scatter of the next); then compound 1; then compound 3.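

Exchanging 3-fluorophenyl for 2-fluorophenyl on this amide-type nitrogen gives a 1.3-fold lower number from compound 2 to compound 4 (0.10 log units; within the scatter), so this assay does not separate the two compounds. The earlier step, a 310-fold higher number from compound 1 to compound 3 (2.49 log units; beyond the scatter), showed that replacing benzyl with isopropyl on such a nitrogen can matter greatly, whereas this pair shows that moving the fluorine between these two placements on the phenyl group need not. No measurement shown explains this result. Plain phenyl and 2-chlorophenyl remain open at this position. So does whether the same exchange holds alongside the longer hydroxyalkyl chain of compound 1.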